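The compounds below may be only part of what the source reports. "The series", "measured", "known", "first", "only" and "open" are said of these compounds alone.

Measured in a functional assay on A2780 cells (Homo sapiens) for cytotoxicity, read by sulforhodamine B assay, with a stated time of 72 h; a higher number here means a weaker inhibitor, a lower number a stronger inhibitor:
- Compound 1 `O=C(NCc1ccc(S(=O)(=O)c2cncc(C(F)(F)F)c2)cc1)N1Cc2ccncc2C1`: 10 nM
- Compound 2 `O=C(NCc1ccc(S(=O)(=O)C2CCN(C3COC3)CC2)cc1)N1Cc2ccncc2C1`: 7.4 nM

So far, compound 2 at 7.4 nM and compound 1 at 10 nM sit within the scatter of each other, so neither can be ranked above the other.

Compound 3 `O=C(NCc1ccc(S(=O)(=O)N2CCC[C@@H](O)C2)cc1)N1Cc2ccncc2C1` keeps the rest of compound 2 but carries 3-hydroxypiperidin-1-yl in place of 1-(oxetan-3-yl)piperidin-4-yl on a sulfonyl sulfur.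

Going by the values given here, only one measured step changes the group at this place: a 1.4-fold lower number from compound 1 to compound 2 (0.13 log units; within the scatter). That single small step is the whole basis for expecting little movement in this assay when this group is exchanged. Among the compounds with values here, no measured compound carries 3-hydroxypiperidin-1-yl, so the range must stay wide.

The expected step is a 1.5-fold higher number from compound 2 to compound 3 (0.17 log units; within the scatter), which would not go beyond the scatter. Compound 3 is estimated at 11 nM, with an expected range from 3 nM to 40 nM.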

Compound 3, half-maximal inhibitory concentration: 70 nM
Compound 3: the middle estimate sits 6.4-fold (0.80 log units) below what was measured; measured number outside the range, above it.
By their numbers in this assay, from the lowest: compounds 2 and 1 (each within the scatter of the next); then compound 3.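

In this assay, the group on this sulfonyl sulfur clearly matters. Exchanging either earlier group for 3-hydroxypiperidin-1-yl moves the number beyond the scatter (a 9.5-fold higher number from compound 2 to compound 3 (0.98 log units; beyond the scatter); a 7.0-fold higher number from compound 1 to compound 3 (0.85 log units; beyond the scatter)), whereas the two quite different groups in compound 1 and compound 2 could not be told apart, so that earlier step was no guide to every exchange here. Nothing available explains why 3-hydroxypiperidin-1-yl stands apart.

The compounds shown leave open whether this step follows the hydroxyl group, the defined stereocentre or the rest of the new ring, since 3-hydroxypiperidin-1-yl differs from the groups it replaces in several ways at once. Plain piperidin-1-yl and the mirror-image 3-hydroxypiperidin-1-yl on the same sulfur would separate these possibilities.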